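The source may hold more compounds than are shown below. What is called first, only, known or untested is meant among the compounds shown, and "the series" means these compounds.

Of the compounds shown here, three have been measured in an assay on RPMI-8866 cells for inhibition of integrin alpha-4/beta-1 (Homo sapiens); a lower number here means a stronger inhibitor, a higher number a weaker inhibitor. Compound 1 `C/C=C/[C@@H](CC(=O)O)NC(=O)[C@@H]1CCCN1S(=O)(=O)c1cc(Cl)cc(Cl)c1` gives 13 nM. Compound 2 `CC(C)[C@H](CC(=O)O)NC(=O)[C@@H]1CCCN1S(=O)(=O)c1cc(Cl)cc(Cl)c1` gives 362 nM. Compound 3 `O=C(O)C[C@@H](NC(=O)[C@@H]1CCN1S(=O)(=O)c1cc(Cl)cc(Cl)c1)c1ccc(F)cc1` gives 3.2 nM. Among these three, compound 1 stands second: compound 3 shows a lower number, compound 2 a far higher one.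

Compound 4 `CC(C)(C)Oc1ccc([C@@H](CC(=O)O)NC(=O)[C@@H]2CCCN2S(=O)(=O)c2cc(Cl)cc(Cl)c2)cc1` is not yet measured; it differs from compound 1 by 4-(tert-butoxy)phenyl in place of prop-1-en-1-yl on a saturated chain carbon bound to an amide-type nitrogen and a saturated chain carbon. Among the compounds with values here, only one measured step touches this carbon, and only indirectly: a 28-fold higher number from compound 1 to compound 2 (1.44 log units; beyond the scatter), where a saturated branched group entered instead. Compound 3 carries an aryl group on the saturated chain carbon bound to the amide-type nitrogen but also differs from compound 1 elsewhere, so its lower number can only hint that an aryl group is tolerated. For compound 4 a step of a 1.6-fold lower number from compound 1 to compound 4 (0.21 log units; within the scatter) in this assay is expected. The estimate for compound 4 is 8 nM, within 2 nM to 40 nM.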

Compound 4, half-maximal inhibitory concentration: 0.53 nM
The estimate for compound 4 lay 15-fold (1.18 log units) above the measured number; the measured number lies below the stated range.
By their numbers in this assay, from the lowest: compound 4; then compound 3; then compound 1; then compound 2.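

In this assay, replacing prop-1-en-1-yl with 4-(tert-butoxy)phenyl gives a 25-fold lower number from compound 1 to compound 4 (1.39 log units; beyond the scatter). This shows that the saturated chain carbon bound to an amide-type nitrogen and a saturated chain carbon accepts a group of 11 heavy atoms with an aromatic ring, and that the number there can fall as well as rise, as in a 28-fold higher number from compound 1 to compound 2 (1.44 log units; beyond the scatter). Nothing measured here accounts for this drop.

The compounds shown leave open how much of the step belongs to the ring and how much to the tert-butoxy group, since a plain phenyl group on this carbon is not among them. From the compounds shown here alone, whether a methoxy group or an amine could stand in place of the tert-butoxy group also remains open.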